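Naphthalen-1-yl in place of 3-methylphenyl: compound 4

The source may report more compounds than this note shows. Statements on the series, on what has been measured and on what is new or still open speak of the compounds shown alone.

Going by the values given here, compound 3 `Cc1cccc(-c2cn3ccnc3c(-c3ccc4ncn(Cc5ccccc5)c4c3)n2)c1` gives 24.8% in a functional assay on PC-3 cells (Homo sapiens) for inhibition, read by sulforhodamine B assay, with a stated time of 48 h, tested at 10 uM (a higher number here means more inhibition at the concentration tested (going by the name of the read-out), a lower number less inhibition), the second highest of the three numbers measured so far. Compound 1 `CC(=O)c1ccc(-c2cn3ccnc3c(-c3ccc4ncn(C5CCCCC5)c4c3)n2)cc1` gives 17.9% in this assay, within the scatter of compound 3. Among the compounds with values here, compound 2 `CCc1ccc(-c2cn3ccnc3c(-c3ccc4ncn(Cc5ccccc5)c4c3)n2)cc1` gives 50.4% in this assay, and the step of a number 25.6 percentage points lower from compound 2 to compound 3 (beyond the scatter) is the one measured change at the same position. Compound 4 `c1ccc(Cn2cnc3ccc(-c4nc(-c5cccc6ccccc56)cn5ccnc45)cc32)cc1` differs from compound 3 by naphthalen-1-yl in place of 3-methylphenyl on an aromatic carbon. Within the data shown here, the only bearing step, a number 25.6 percentage points lower from compound 2 to compound 3 (beyond the scatter), shows that 3-methylphenyl in place of 4-ethylphenyl lowered inhibition beyond the scatter; no measured step tests a second fused carbon ring here, so the direction for compound 4 is uncertain. Compound 4 is expected to give about 32% in this assay, between 10% and 55%, an expected step of a number 7.2 percentage points higher from compound 3 to compound 4 (within the scatter) that is modest and more likely upward than not.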

Compound 4, a percentage reported as inhibition, at one concentration (the size of the read-out at that concentration, not a potency): 31.4%
Compound 4: the middle estimate sits 0.6 percentage points above what was measured, within the range that was stated.
By their numbers in this assay, from the lowest: compounds 1, 3 and 4 (each within the scatter of the next, the first and the last beyond it); then compound 2.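

In this assay, naphthalen-1-yl in place of 3-methylphenyl adds a second fused carbon ring at this position without a change beyond the scatter (a number 6.6 percentage points higher from compound 3 to compound 4 (within the scatter)). Naphthalen-1-yl still does not match 4-ethylphenyl (a number 19 percentage points lower from compound 2 to compound 4 (beyond the scatter)), so among compounds 2, 3 and 4, only compound 2 stands apart from the other two. No evidence bears on why these groups differ.

Going by these compounds, it remains open whether a longer chain than the ethyl of 4-ethylphenyl, or an amine or a carboxylic acid in its place, would match or pass compound 2.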